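Compound 3 to Compound 4 at a Single Concentration

The compounds below may be only part of what the source reports. "The series", "measured", "known", "first", "only" and "open" are said of these compounds alone.

Of the compounds shown here, three sharing one core have been measured. In a functional assay on HOP-62 cells (Homo sapiens) for inhibition, read by sulforhodamine B assay, with a stated time of 48 h, tested at 0.1 uM (on this read-out higher numbers stand for a weaker effect at the one concentration tested and lower numbers for a stronger effect), compound 1 `COc1cc(Cl)cc(-c2nn(-c3cccc(NC(=O)Nc4ccc(Cl)c(C(F)(F)F)c4)c3)cc2-c2ccncc2)c1` gives 104%, compound 2 `COc1cc(Cl)cc(-c2nn(-c3cccc(NC(=O)Nc4ccc(Cl)c(Cl)c4)c3)cc2-c2ccncc2)c1` gives 94%, and compound 3 `COc1cc(Cl)cc(-c2nn(-c3cccc(NC(=O)Nc4cccc(C(F)(F)F)c4)c3)cc2-c2ccncc2)c1` gives 97%. Compound 3 stands second highest of the three numbers; its nearest neighbour is compound 2, where a number 3 percentage points higher from compound 2 to compound 3 (within the scatter), and its furthest is compound 1, where a number 7 percentage points lower from compound 1 to compound 3 (within the scatter). The remaining step, a number 10 percentage points lower from compound 1 to compound 2 (within the scatter), is likewise within the scatter, so none of the three compounds can be separated from the others on this read-out.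

Compound 4 `COc1cc(Cl)cc(-c2nn(-c3cccc(NC(=O)c4cccc(C(F)(F)F)c4)c3)cc2-c2ccncc2)c1` has not been measured. It differs from compound 3 by 3-(trifluoromethyl)phenyl in place of (3-(trifluoromethyl)phenyl)amino on a carbonyl carbon. For the measured compounds named here, no measured step touches the carbonyl carbon or its neighbours; the three steps on record all concern the aromatic ring at the far end and all lie within the scatter. On that basis the step from compound 3 to compound 4 is expected to be no change at the digits printed from compound 3 to compound 4 (within the scatter), with no direction beyond the scatter. Compound 4 is therefore estimated at 97%, within a range from 84% to 110%.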

Compound 4, a percentage reported as activity, at one concentration (the size of the read-out at that concentration, not a potency): 101%
For compound 4 the middle estimate is 4 percentage points below the measured one; the measured number falls inside the stated range.
By their numbers in this assay, from the lowest: compounds 2, 3, 4 and 1 (each within the scatter of the next).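

For the compounds shown here, the change at the carbonyl carbon, which no earlier step had touched, takes out the (3-(trifluoromethyl)phenyl)amino group and its nitrogen, and in this assay the outcome is a number 4 percentage points higher from compound 3 to compound 4 (within the scatter) for this exchange alone. The two steps that alter the far aromatic ring together with this change read a number 7 percentage points higher from compound 2 to compound 4 (within the scatter) and a number 3 percentage points lower from compound 1 to compound 4 (within the scatter) so compound 4 cannot be separated from any of compounds 1, 2 and 3, with or without the amino group on the carbonyl carbon. Nothing at hand explains this result.

From the compounds shown here alone, it remains open whether a different group on this carbonyl carbon, such as a morpholine, a carboxylic acid or a longer alkyl chain, would give a step beyond the scatter. Going by these compounds, whether these four compounds separate at any other concentration also remains open.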